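Compound 4: Swapping the Amine Group on a Limit Compound

This account rests on a few compounds, and the source may have more. Where it says the series, first, only, none or still open, it means among the compounds named here.

Measured in a functional assay on MDA-MB-435 cells (Homo sapiens) for cytotoxicity, read by MTT assay, with a stated time of 72 h; a higher number here means a weaker inhibitor, a lower number a stronger inhibitor:
- Compound 1 `N[C@H]1CC[C@H](Nc2c(C(=O)NCc3ccco3)nc(Br)c3cccnc23)CC1`: > 10000 nM (a limit)
- Compound 2 `C[C@@H](Nc1c(C(=O)NCc2ccc(F)cc2)nc(Br)c2cccnc12)c1ccccc1`: > 20000 nM (a limit)
- Compound 3 `CN(C)CCCNc1c(C(=O)NCc2ccc(F)cc2)nc(Br)c2cccnc12`: 7000 nM

In this assay compound 2 gives > 20000 nM, and this is a limit, not a number. Its true position is therefore unknown, and any step from it can only be read as a bound.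

Compound 4 `N[C@H]1CC[C@H](Nc2c(C(=O)NCc3ccc(F)cc3)nc(Br)c3cccnc23)CC1` is compound 2 with 4-aminocyclohexyl in place of 1-phenylethyl on a nitrogen on an aromatic ring.

One measured step changes the same place, with 3-(dimethylamino)propyl entering: an at least 2.8-fold lower number from compound 2 to compound 3 (0.45 log units; beyond the scatter). Compound 1 carries the same 4-aminocyclohexyl group but differs from compound 4 elsewhere. Compound 1 gives > 10000 nM, which is also a limit.

A step of similar modest size towards a lower number is therefore expected, though with little certainty, and compound 4 may itself reach a limit. The expected change is an at least 2.5-fold lower number from compound 2 to compound 4 (0.39 log units; beyond the scatter). For compound 4 the estimated value is 8000 nM, with an expected range from 2500 nM to 25000 nM.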

Compound 4, half-maximal inhibitory concentration: 6000 nM
The estimate for compound 4 lay 1.3-fold (0.12 log units) above the measured number; low and high end bracket the measured number.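

With this assay as the measure, 4-aminocyclohexyl in place of 1-phenylethyl gives an at least 3.3-fold lower number from compound 2 to compound 4 (0.52 log units; beyond the scatter), which can be read only as a bound because compound 2 stands at a limit: the limit of > 20000 nM in this assay, at which 1 of the 4 values shown sits.

A ring-bearing group with an amine thus gives a measured value on this nitrogen, and it cannot be told apart from the open chain of compound 3: a 1.2-fold lower number from compound 3 to compound 4 (0.07 log units; within the scatter).

Compound 1 goes against any reading that 4-aminocyclohexyl alone secures a measured value, yet an at least 1.6-fold lower number from compound 1 to compound 4 (0.22 log units; that floor lies within the scatter) has only a floor, so the change from furan-2-yl to 4-fluorophenyl remains unresolved.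

The compounds shown leave open whether the amine or the saturated ring matters more. A plain cyclohexyl or a 4-hydroxycyclohexyl group on this nitrogen would separate the two.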